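This account rests on a few compounds, and the source may have more. Where it says the series, first, only, none or still open, it means among the compounds named here.

Compound 1 `COc1ccc(N/C=C\C(=O)c2nc(-c3ccc(F)cc3)n3ccccc23)cc1OC`: in a functional assay on BT-474 cells (Homo sapiens) for cytotoxicity, read by MTT assay, with a stated time of 48 h (a higher number here means a weaker inhibitor, a lower number a stronger inhibitor), compound 1 gives > 30000 nM, which is a limit of the assay rather than a number.
Compound 2 `O=C(/C=C\Nc1ccc2cc[nH]c2c1)c1nc(-c2ccc(C(F)(F)F)cc2)n2ccccc12`: in this assay compound 2 gives > 30000 nM, again a limit.
Compound 3 `O=C(/C=C\Nc1cnc2ccccc2c1)c1nc(-c2ccccc2)n2ccccc12`: in this assay compound 3 gives 19700 nM.

Compound 1 thus sits at the edge of what the assay can report, (the limit of > 30000 nM in this assay, at which 2 of the 3 values shown sit), so only weak inhibition is known for it. Going by the values given here, compound 3, the one compound with an actual number, is also a weak inhibitor. Compound 4 `O=C(/C=C\Nc1ccc(F)cc1)c1nc(-c2ccc(F)cc2)n2ccccc12` differs from compound 1 by 4-fluorophenyl in place of 3,4-dimethoxyphenyl on an amine nitrogen. Among the compounds with values here, no measured pair of compounds shows the effect of such a swap, so there is nothing to lean on. The step of an at least 1.2-fold lower number from compound 1 to compound 4 (0.07 log units; that floor lies within the scatter) is expected to stay within the usual scatter, with no clear direction. Compound 4 is therefore estimated at about 25000 nM, in the range 8000 nM to 60000 nM.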

Compound 4, half-maximal inhibitory concentration: 16900 nM
Estimate against measurement, compound 4: 1.5-fold (0.17 log units) above; the measured number falls inside the stated range.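

Going by these compounds alone, replacing 3,4-dimethoxyphenyl with 4-fluorophenyl on the amine nitrogen gives the only direct comparison at this position: in this assay, the change gives an at least 1.7-fold lower number from compound 1 to compound 4 (0.24 log units; that floor lies within the scatter). The swap yields a measured number, but it cannot be called a real gain. Compound 1 has only a limit, so the true size of the step remains unknown because that limit gives only a floor: the limit of > 30000 nM in this assay, at which 2 of the 4 values shown sit.

Going by these compounds, whether an amine or a carboxylic acid in place of the fluorine would change the number remains open. So does whether this swap would act the same way with other groups elsewhere on the shared core.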